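Pyridin-3-yl for Oxetan-3-yl on the Ring Amine

This account rests on a few compounds, and the source may have more. Where it says the series, first, only, none or still open, it means among the compounds named here.

Of the compounds shown here, two have been measured in an assay on a protein complex for inhibition of ubiquitin carboxyl-terminal hydrolase 1/WD repeat-containing protein 48 (Homo sapiens), read by fluorescence; a higher number here means a weaker inhibitor, a lower number a stronger inhibitor. Compound 1 `Cc1ccc(CNc2nc(-c3ccccc3C(F)(F)F)nc3ccccc23)s1` gives 5100 nM in this assay. Compound 2 `Cc1cnc(-c2ccccc2C(C)C)nc1NCC1CCN(C2COC2)CC1` gives 13600 nM in this assay, which is the higher of the two numbers, and the gap to compound 1 lies beyond the usual scatter. Within the data shown here, the two compounds share no single point of difference, so their values can only be set side by side and no step between them can be read.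

Compound 3 `Cc1cnc(-c2ccccc2C(C)C)nc1NCC1CCN(c2cccnc2)CC1` is the next compound to be measured. It differs from compound 2 in one place: pyridin-3-yl in place of oxetan-3-yl on an amine nitrogen in a ring. Among the measured compounds shown here, no measured pair in this set carries a change of this kind, so nothing here tells how much the number should move, or in which direction. In the absence of such a precedent, compound 3 is expected to stay close to compound 2, with a step from a 1.5-fold lower number from compound 2 to compound 3 (0.18 log units; within the scatter) that does not clearly exceed the scatter. On this basis the estimate for compound 3 in this assay is 9000 nM, with a range from 2500 nM to 32000 nM.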

Compound 3, half-maximal inhibitory concentration: 80 nM
Beside the measured number, compound 3's estimate is 110-fold (2.05 log units) above it; the measured number lies below the stated range.
By their numbers in this assay, from the lowest: compound 3; then compound 1; then compound 2.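

In this assay, among these compounds, the group on the amine nitrogen in a ring proves to be a strong determinant of the number: the single change to pyridin-3-yl from oxetan-3-yl gives a 170-fold lower number from compound 2 to compound 3 (2.23 log units; beyond the scatter), with the rest of the structure unchanged. Compounds 1 and 2 share no single point of difference, so they could not show that this position responds at all, whereas this pair shows that it can respond far beyond the scatter. The two groups match in their counts of hydrogen-bond donors and acceptors and in having no net charge, differing instead in ring size, aromaticity and the hetero atom, but no measurement here explains the size of the step.

How a plain phenyl or a pyridin-4-yl group would stand at this place remains open, so the compounds shown cannot separate a contribution of the aromatic ring from one of its nitrogen and where that nitrogen sits. Among the compounds shown here, with only this one pair, it also remains open whether a step of this size would recur with other changes at this position or on another core.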